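Trading a Methyl for Trifluoromethyl on the Shared Core

The source may hold more compounds than are shown below. What is called first, only, known or untested is meant among the compounds shown, and "the series" means these compounds.

Of the compounds shown here, two sharing one core have been tested in an assay on HEK293 cells for inhibition of solute carrier family 22 member 12 (Homo sapiens), read by scintillation counting, with a stated time of 12 min; on this read-out lower numbers stand for stronger inhibition and higher numbers for weaker inhibition. Compound 1 `N#CCCc1ccc2nccc(SC3(C(=O)O)CCC3)c2c1` gives 2760 nM. Within the data shown here, compound 2 `Cc1ccc2nccc(SC3(C(=O)O)CCC3)c2c1` gives 343 nM, the lower of the two numbers; the only measured step, an 8.0-fold lower number from compound 1 to compound 2 (0.91 log units; beyond the scatter), separates them, which is beyond the scatter. Compound 3 `O=C(O)C1(Sc2ccnc3ccc(C(F)(F)F)cc23)CCC1` is not yet measured. It differs from compound 2 in one place: trifluoromethyl in place of methyl on an aromatic carbon. Among the measured compounds shown here, no measured step touches this kind of change; the single step from compound 1 to compound 2 concerns a saturated chain carbon rather than the aromatic ring, so it gives little guidance here. The expectation is therefore a step of at most modest size, with direction uncertain, written as a 1.4-fold lower number from compound 2 to compound 3 (0.14 log units; within the scatter). Compound 3 is expected to give about 250 nM in this assay, within a range from 80 nM to 800 nM.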

Compound 3, half-maximal inhibitory concentration: 61.2 nM
For compound 3 the middle estimate is 4.1-fold (0.61 log units) above the measured one; the whole stated range lies above it.
By their numbers in this assay, from the lowest: compound 3; then compound 2; then compound 1.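

In this assay, replacing methyl with trifluoromethyl on this aromatic carbon gives a 5.6-fold lower number from compound 2 to compound 3 (0.75 log units; beyond the scatter), so the position responds to a change of this kind, not only to the loss of a chain. The earlier pair alone could suggest that a smaller group here simply gives a lower number, but trifluoromethyl has more heavy atoms than methyl and still gives the lower number, and replacing 2-cyanoethyl with it gives a 45-fold lower number from compound 1 to compound 3 (1.65 log units; beyond the scatter). Nothing measured here explains why trifluoromethyl does better.

On these data alone, whether another group at this position, such as a chlorine atom, a methoxy group or an amine, would give a lower number still remains open. So does whether trifluoromethyl would bring the same gain if other parts of the shared core were changed.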